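A few compounds are considered here, and "the series" means these few. Any claim that something is new, unique, unknown or untested is made for them only; others in the source may bear on it.

Measured compounds:
compound 1 `O=c1sc2cc(NS(=O)(=O)c3ccc4ccccc4c3)ccc2n1CCN1CCCC1` — in an assay on HEK293 cells for displacement of a labelled ligand from 5-hydroxytryptamine receptor 6 (Homo sapiens), read by radioligand binding, with a stated time of 60 min, tested at 100 nM (a lower number here means less inhibition, a higher number more inhibition at the concentration tested (going by the name of the read-out)), compound 1 gives 0%
compound 2 `O=c1sc2cc(NS(=O)(=O)c3ccc4ccccc4c3)ccc2n1CCN1CCCCC1` — in this assay compound 2 gives 4%
compound 3 `O=c1sc2cc(S(=O)(=O)Nc3ccccc3)ccc2n1CCN1CCCC1` — in this assay compound 3 gives 37%

Compound 1 and compound 2 share one core and differ in a single place: piperidin-1-yl in place of pyrrolidin-1-yl on a saturated chain carbon, two bonds along the chain from an aromatic nitrogen. The step in this assay is a number 4 percentage points higher from compound 1 to compound 2 (within the scatter), so the two numbers cannot be told apart.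

Compound 3 sits on a different core, and the difference between the two cores is not broken down here; what the values show is that compound 3 stands highest of the three, with compound 2 nearest and compound 1 furthest, both gaps beyond the scatter.

Compound 4 `O=c1sc2cc(S(=O)(=O)Nc3ccccc3)ccc2n1CCN1CCCCC1` is not yet measured in this assay. It stands to compound 3 exactly as compound 2 stands to compound 1: piperidin-1-yl in place of pyrrolidin-1-yl on a saturated chain carbon, two bonds along the chain from an aromatic nitrogen. The place is the same in both pairs, so this is the same change. Within the data shown here, the only measured instance of it is the step from compound 1 to compound 2, which stayed within the scatter, so compound 4 is expected to land close to compound 3 in this assay. Among the measured compounds shown here, the expected step is a number 3 percentage points higher from compound 3 to compound 4 (within the scatter), resting on the step of a number 4 percentage points higher from compound 1 to compound 2 (within the scatter) as the sole precedent. For compound 4 the estimate in this assay is 40%, with a range from 25% to 55% expected to hold most repeats.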

Compound 4, a percentage reported as inhibition, at one concentration (the size of the read-out at that concentration, not a potency): 7%
Beside the measured number, compound 4's estimate is 33 percentage points above it; the measured number lies below the stated range.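

In this assay, piperidin-1-yl in place of pyrrolidin-1-yl on the core of compound 3 gives a number 30 percentage points lower from compound 3 to compound 4 (beyond the scatter), and the change does not read the same on the two cores: the same change on two cores in this assay, a number 4 percentage points higher (within the scatter) from compound 1 to compound 2 and a number 30 percentage points lower (beyond the scatter) from compound 3 to compound 4, 34 percentage points apart, beyond the scatter of two such steps

A step measured on one core is therefore no safe guide to the same change on the other in this series, and the small step on the core of compound 1 gave no warning of the fall on the core of compound 3. The comparison does not show which part of the cores separates the two outcomes, and it gives no general rule, as it rests on one pair per core, with the pair on the core of compound 1 sitting low in the read-out, where compound 1 gives 0% and compound 2 gives 4%, leaving little room for a fall to show.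

On these data alone, it remains open how morpholin-4-yl or an open-chain amine such as diethylamino would read on either core, and whether a longer chain to the amine would keep the gap seen between compound 3 and compound 4. Also open, as far as these compounds go, is whether that gap, read at a single concentration, would hold at other concentrations.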